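The source may hold more compounds than are shown below. What is called first, only, known or untested is meant among the compounds shown, and "the series" means these compounds.

Three compounds built on the same core, each with a different group on the amine nitrogen of the six-membered non-aromatic ring with two nitrogens, have been tested in a functional assay on the whole organism (strain CF-1 albino) with Mus musculus as the target, with a stated time of 4 h; on this read-out higher numbers stand for an effect only at larger amounts of compound and lower numbers for an effect already at smaller amounts. Compound 1 `O=C1CC(c2ccccc2Br)C(=O)N1CN1CCN(c2ccccc2Cl)CC1` gives 300 mg/kg, and compound 2 `O=C1CC(c2ccccc2Br)C(=O)N1CN1CCN(c2cccc(C(F)(F)F)c2)CC1` gives 300 mg/kg. Compound 3 `O=C1CC(c2ccccc2Br)C(=O)N1CN1CCN(c2ncccn2)CC1` gives 100 mg/kg, the lowest of the three numbers. The gaps that set it apart are a 3.0-fold lower number from compound 1 to compound 3 (0.48 log units; beyond the scatter) and a 3.0-fold lower number from compound 2 to compound 3 (0.48 log units; beyond the scatter), while no change at the digits printed from compound 1 to compound 2 (within the scatter).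

Compound 4 `O=C1CC(c2ccccc2Br)C(=O)N1CN1CCN(C2CCCCC2)CC1` differs from compound 3 by cyclohexyl in place of pyrimidin-2-yl on an amine nitrogen in a ring. Among the compounds with values here, the measured steps that bear on this all swap one six-membered aromatic group for another at this nitrogen; none introduces a non-aromatic ring there, so no close precedent exists. Given that a swap of the aryl group moved the number modestly at most, a modest rise back toward compounds 1 and 2 is expected, as a 2.0-fold higher number from compound 3 to compound 4 (0.30 log units; within the scatter). Compound 4 is therefore estimated at 200 mg/kg, within a range from 100 mg/kg to 500 mg/kg.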

Compound 4, minimum effective dose: 100 mg/kg
Estimate against measurement, compound 4: 2.0-fold (0.30 log units) above; the measured number falls inside the stated range.
By their numbers in this assay, from the lowest: compounds 3 and 4 (each within the scatter of the next); then compounds 1 and 2 (each within the scatter of the next).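

The ring on this nitrogen need not be aromatic: in this assay the swap to cyclohexyl gives no change at the digits printed from compound 3 to compound 4 (within the scatter), even though a carbon-only non-aromatic ring with no hydrogen-bond acceptors replaces an aromatic ring with two nitrogens. Cyclohexyl also stands apart from both substituted phenyl groups, with a 3.0-fold lower number from compound 2 to compound 4 (0.48 log units; beyond the scatter) and a 3.0-fold lower number from compound 1 to compound 4 (0.48 log units; beyond the scatter), so the ring nitrogens of pyrimidin-2-yl are not needed to reach this lower number. Nothing measured here explains this pattern.

A plain unsubstituted phenyl group on this nitrogen could show whether it falls with compound 3 and compound 4 or with compound 1 and compound 2. A small open chain such as methyl, or a benzyl group, would test whether a ring directly on this nitrogen matters at all.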